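Halogen swap on the hydrazide aryl ring

The source may hold more compounds than are shown below. What is called first, only, known or untested is meant among the compounds shown, and "the series" means these compounds.

Going by the values given here, compound 2 `CC(C)(C)N(NC(=O)c1ccc(F)cc1)C(=O)c1ccccc1Cl` sits at the higher end of the two numbers so far: in an assay on cells for agonist activity at ecdysone receptor (Bombyx mori), read by a luciferase reporter, with a stated time of 24 h (a lower number here means that less compound is needed, a higher number that more compound is needed for the effect), compound 2 gives 389 nM, while compound 1 `CC(C)(C)N(NC(=O)c1cccc(Cl)c1)C(=O)c1ccccc1Cl` gives 155 nM. Among the compounds with values here, the only measured step, a 2.5-fold higher number from compound 1 to compound 2 (0.40 log units; beyond the scatter), changed the aryl group on the hydrazide carbonyl rather than a single substituent. Compound 3 `CC(C)(C)N(NC(=O)c1ccc(Cl)cc1)C(=O)c1ccccc1Cl` is the next point in the series; the change from compound 2 reads (chloro in place of fluoro on an aromatic carbon). Within the data shown here, no measured pair isolates this exact swap, so the one step available bears on it only indirectly, as a halogen-bearing aryl variation of the same size class. With a chlorine present again on this ring, the expectation is a step back toward compound 1, of modest size or none beyond the scatter, that is a 1.8-fold lower number from compound 2 to compound 3 (0.25 log units; within the scatter). Compound 3 is therefore estimated at 220 nM, with a plausible range of 90 nM to 550 nM.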

Compound 3, half-maximal effective concentration: 115 nM
Compound 3: middle estimate off by 1.9-fold (0.28 log units), on the high side; low and high end bracket the measured number.
By their numbers in this assay, from the lowest: compounds 3 and 1 (each within the scatter of the next); then compound 2.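

In this assay the swap of a single atom, chloro in place of fluoro on an aromatic carbon para to a large group, gives a 3.4-fold lower number from compound 2 to compound 3 (0.53 log units; beyond the scatter) and so shows that the choice of halogen at this place can shift the number beyond the scatter. The change from 3-chlorophenyl to 4-chlorophenyl gives a 1.3-fold lower number from compound 1 to compound 3 (0.13 log units; within the scatter) and stays within the scatter, so this assay does not separate these two chlorine-bearing aryl groups. No available evidence bears on the reason for the difference between the chloro and fluoro compounds.

As far as these compounds go, it remains open whether a bromo, methyl or methoxy group at the same place would stay level with the chloro compound or move away from it. The compounds shown also leave open whether the fluoro-to-chloro step keeps its size on a different core.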